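Acetamido on the phenyl of compound 1

The source may report more compounds than this note shows. Statements on the series, on what has been measured and on what is new or still open speak of the compounds shown alone.

Compound 1 `C[C@@H](NCC1CCN(CCCc2c[nH]c3ccc(-n4cnnc4)cc23)CC1)c1ccccc1` is the reference point of this pair. Within the data shown here, in an assay on CHO cells for displacement of a labelled ligand from 5-hydroxytryptamine receptor 1D (Homo sapiens) (a lower number here means a stronger inhibitor, a higher number a weaker inhibitor), compound 1 gives 1.4 nM, the lowest of the two numbers measured so far. Among the measured compounds shown here, its only neighbour is compound 2 `CN(Cc1cccs1)C1CCN(CCCc2c[nH]c3ccc(-n4cnnc4)cc23)CC1`, which in this assay gives 4.3 nM; the step of a 3.1-fold higher number from compound 1 to compound 2 (0.49 log units; beyond the scatter) is modest but beyond the scatter.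

Compound 3 `CC(=O)Nc1ccc([C@@H](C)NCC2CCN(CCCc3c[nH]c4ccc(-n5cnnc5)cc34)CC2)cc1` is compound 1 with the change acetamido in place of hydrogen on an aromatic carbon of a six-membered aromatic ring of carbon only, so that 1-phenylethyl becomes 1-(4-acetamidophenyl)ethyl. For the measured compounds named here, no measured step covers a substituent change on this ring; the single step in hand exchanges the whole amine portion and gives no guidance for adding a group to the phenyl. With the core and the amine untouched, the expectation is a step of no clear size beyond the scatter in this assay, with a wide range to reflect the lack of a precedent.

Compound 3 is therefore estimated at 1.6 nM (range 0.5 nM to 5 nM), the expected step being a 1.1-fold higher number from compound 1 to compound 3 (0.06 log units; within the scatter).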

Compound 3, half-maximal inhibitory concentration: 1.5 nM
Estimate against measurement, compound 3: 1.1-fold (0.03 log units) above; the measured number falls inside the stated range.
By their numbers in this assay, from the lowest: compounds 1 and 3 (each within the scatter of the next); then compound 2.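

In this assay, a 1.1-fold higher number from compound 1 to compound 3 (0.03 log units; within the scatter), so acetamido on the phenyl, para to a large group, leaves no readable mark on the number, even though it brings a hydrogen-bond donor and a hydrogen-bond acceptor with it. Among these compounds, until now the only step in hand was the exchange of the whole amine portion, a 3.1-fold higher number from compound 1 to compound 2 (0.49 log units; beyond the scatter), which said nothing about the phenyl itself; compound 3 gives the first reading for this ring and shows that 1-(4-acetamidophenyl)ethyl and 1-phenylethyl cannot be told apart here. Nothing measured alongside this result accounts for the flat step, and this single pair gives no reason for it.

One substituent at one place cannot show how much room this position has in general: a free amine, a carboxylic acid or a longer acyl chain such as butanamido at the same place could still separate from compound 1. Also open, as far as these compounds go, is whether the amide hydrogen counts for anything, which an N-methylacetamido group would test, and whether acetamido reads the same at other places on the phenyl.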